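Adding a methylpyrazolyl group to compound 2

This account rests on a few compounds, and the source may have more. Where it says the series, first, only, none or still open, it means among the compounds named here.

Going by the values given here, in a functional assay on B16-F0 cells (Mus musculus) for inhibition, read by CCK-8 assay, with a stated time of 48 h (on this read-out lower numbers stand for stronger inhibition and higher numbers for weaker inhibition), compound 2 `COc1cc(-c2ccnc3cc(-c4ccccc4)nn23)cc(OC)c1OC` gives 4730 nM, the highest number of the three measured so far. Compound 1 `COc1cc(-c2ccnc3cc(-c4ccc(C)c(C)c4)nn23)cc(OC)c1OC` gives 391 nM, and compound 3 `COc1cc(-c2ccnc3cc(-c4ccc5cc[nH]c5c4)nn23)cc(OC)c1OC` gives 55 nM. The change to compound 4 `COc1cc(-c2ccnc3cc(-c4ccc(-c5cnn(C)c5)cc4)nn23)cc(OC)c1OC` is 1-methyl-1H-pyrazol-4-yl in place of hydrogen on an aromatic carbon, with 1-methyl-1H-pyrazol-4-yl in place of hydrogen on an aromatic carbon, para to a large group. Two large steps bear on it. Phenyl in place of 3,4-dimethylphenyl gives a 12-fold higher number from compound 1 to compound 2 (1.08 log units; beyond the scatter), while 1H-indol-6-yl in place of phenyl gives an 86-fold lower number from compound 2 to compound 3 (1.93 log units; beyond the scatter). Neither involves the entering group, so the size remains uncertain. A large downward step is expected, a 9.5-fold lower number from compound 2 to compound 4 (0.98 log units; beyond the scatter). For compound 4 the estimate is 500 nM, with an expected range of 90 nM to 2500 nM.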

Compound 4, half-maximal inhibitory concentration: 1240 nM
The estimate for compound 4 lay 2.5-fold (0.39 log units) below the measured number; the measured number falls inside the stated range.
By their numbers in this assay, from the lowest: compound 3; then compound 1; then compound 4; then compound 2.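

In this assay, 1-methyl-1H-pyrazol-4-yl in place of hydrogen, para to a large group, gives a 3.8-fold lower number from compound 2 to compound 4 (0.58 log units; beyond the scatter). Going by these compounds alone, none of the earlier compounds carries a separate ring at this place, and compound 4 shows that a five-membered aromatic ring with 2 hetero atoms can sit there while the number still falls. Nothing available explains this gain. On these data alone, whether the methyl on the pyrazole contributes remains open. So does whether a morpholine or a carboxylic acid at the same place would move the number further.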